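A few compounds are considered here, and "the series" means these few. Any claim that something is new, unique, unknown or untested is made for them only; others in the source may bear on it.

Compound 1, `O=C(NCCCCN1CCN(c2cccc(Cl)c2)CC1)c1ccc(-c2ccsc2)cc1`, was measured in an ADME assay on microsomes from liver (Rattus norvegicus) for metabolic stability, read by LC-MS, using NADPH (on this read-out higher numbers stand for a longer-lived compound and lower numbers for a shorter-lived compound), and gives 0.468 h. Among the three compounds measured so far it stands second highest. Its nearest neighbour is compound 2, `O=C(NCCCCN1CCN(c2ccc(Cl)cc2)CC1)c1ccc(-c2ccsc2)cc1`, which gives 0.837 h in this assay; the step of a 1.8-fold higher number from compound 1 to compound 2 (0.25 log units; within the scatter) lies within the scatter. Compound 3, `O=C(NCCCCN1CCN(c2ccccc2O)CC1)c1ccc(-c2ccsc2)cc1`, gives 0.157 h, and the step of a 3.0-fold lower number from compound 1 to compound 3 (0.47 log units; beyond the scatter) is beyond the scatter, as is a 5.3-fold lower number from compound 2 to compound 3 (0.73 log units; beyond the scatter).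

Compound 4, `N#Cc1cccc(N2CCN(CCCCNC(=O)c3ccc(-c4ccsc4)cc3)CC2)c1`, has not yet been measured. It differs from compound 1 in one place: cyano in place of chloro on an aromatic carbon. Among the compounds with values here, none of the measured steps exchanges chloro for cyano, so no step bears on this change directly. The three measured steps all alter the aromatic ring on the amine nitrogen in the ring, and the largest of them, a 5.3-fold lower number from compound 2 to compound 3 (0.73 log units; beyond the scatter), is only modest. The step to compound 4 is therefore expected to be small as well, most likely within the scatter, with no clear direction. For compound 4 the estimate is 0.42 h, expected to lie between 0.16 h and 1.1 h, which would mean an expected step of a 1.1-fold lower number from compound 1 to compound 4 (0.05 log units; within the scatter).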

Compound 4, half-life: > 1 h
Compound 4: only a limit was reported (the forecaster's own chance of this, stated with the estimate: 5%); middle value at least 2.3-fold (0.37 log units) away from the limit.
By their numbers in this assay, from the lowest: compound 3; then compounds 1 and 2 (each within the scatter of the next). At a limit, above all of these: compound 4.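

In this assay, compound 4 gives only a limit, > 1 h, and not a number. Even so, the change from chloro to cyano on this aromatic carbon can be read, as an at least 2.1-fold higher number from compound 1 to compound 4 (0.32 log units; beyond the scatter), and it is the first step here that goes up beyond the scatter, since the only such steps among the earlier compounds went down, to the 2-hydroxyphenyl compound. The gap to that compound widens to an at least 6.3-fold higher number from compound 3 to compound 4 (0.80 log units; beyond the scatter), but an at least 1.1-fold higher number from compound 2 to compound 4 (0.07 log units; that floor lies within the scatter) leaves it unsettled whether the 3-cyanophenyl compound truly outlasts the 4-chlorophenyl one.

As far as these compounds go, whether a trifluoromethyl or a carboxylic acid in place of chloro on this aromatic carbon would give a similar rise remains open. How long compound 4 actually lasts also remains open: the limit of > 1 h in this assay, at which 1 of the 4 values shown sits.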